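Swapping chloro for methyl on a quinoxaline dioxide amide

The compounds below may be only part of what the source reports. "The series", "measured", "known", "first", "only" and "open" are said of these compounds alone.

Compound 1 `N#Cc1c(NS(=O)(=O)c2ccc([N+](=O)[O-])cc2)[n+]([O-])c2cc(Cl)c(Cl)cc2[n+]1[O-]`: in an ADME assay on cells (Peritoneal macrophage cell, Mus musculus) for cytotoxicity, read by trypan blue exclusion, with a stated time of 48 h (on this read-out lower numbers stand for higher toxicity in this test and higher numbers for lower toxicity in this test), compound 1 gives 89100 nM.
Compound 2 `CC(=O)Oc1ccccc1C(=O)Nc1c(C#N)[n+]([O-])c2ccccc2[n+]1[O-]`: in this assay compound 2 gives "not determined" (no result reported).
Compound 3 `CC(=O)Oc1ccccc1C(=O)Nc1c(C#N)[n+]([O-])c2cc(Cl)ccc2[n+]1[O-]`: in this assay compound 3 gives "not determined" (no result reported).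
Compound 4 `CC(=O)Oc1ccccc1C(=O)Nc1c(C#N)[n+]([O-])c2cc(C)ccc2[n+]1[O-]`: not yet measured.

Only compound 1 carries a number here. Compound 3 stands without one, as does compound 2, so nothing shows how compound 3 compares with compound 1. The change from compound 3 to compound 4 is methyl in place of chloro on an aromatic carbon. Among the compounds with values here, no pair of measured compounds shows what such a swap does to this read-out, so the expected step is unknown in direction; a change within the usual scatter seems as likely as a larger one. Within the data shown here, compound 4 is therefore expected to fall near the single known value, estimated at 80000 nM with a range from 20000 nM to 300000 nM.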

Compound 4, half-maximal cytotoxic concentration: 21700 nM
Beside the measured number, compound 4's estimate is 3.7-fold (0.57 log units) above it; low and high end bracket the measured number.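

Within the data shown here, compound 3 has no single number in this assay, so no step to compound 4 can be read. Going by these compounds, what methyl in place of chloro does to this read-out stays open. No supporting evidence bears on this result.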